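A few compounds are considered here, and "the series" means these few. Any claim that something is new, unique, unknown or untested is made for them only; others in the source may bear on it.

Compound 1 `CCCOC(=O)Nc1ccc([Se]C#N)cc1` was tested in a functional assay on HTB-54 cells (Homo sapiens) for cytotoxicity, read by MTT assay, with a stated time of 72 h (a lower number here means a stronger inhibitor of growth, a higher number a weaker inhibitor of growth), where compound 1 gives 28900 nM. One other compound was measured there, compound 2 `O=C(Nc1ccc([Se][Se]c2ccc(NC(=O)OCc3ccccc3)cc2)cc1)OCc1ccccc1`, and in this assay compound 2 gives 23800 nM. Of these two numbers compound 1 carries the larger one, but the gap to compound 2 lies within the scatter, so the two cannot be told apart. Compound 3 `CC(C)COC(=O)Nc1ccc([Se]C#N)cc1` has not yet been measured. It differs from compound 1 in one place: methyl in place of hydrogen on a saturated chain carbon bound to two saturated chain carbons. Going by the values given here, no measured pair shows what such a change does in this assay, so there is no step to lean on. One carbon added to the carbamate chain is expected to leave the number near where compound 1 stands, with no shift beyond the scatter. The step that this estimate means is a 1.1-fold lower number from compound 1 to compound 3 (0.05 log units; within the scatter). Compound 3 is therefore expected to give about 26000 nM in this assay, with a range from 10000 nM to 70000 nM.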

Compound 3, concentration for 50% growth inhibition: 27100 nM
The estimate for compound 3 lay 1.0-fold (0.02 log units) below the measured number, within the range that was stated.
By their numbers in this assay, from the lowest: compounds 2, 3 and 1 (each within the scatter of the next).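

In this assay, the pair gives a reading for this change at this position, a 1.1-fold lower number from compound 1 to compound 3 (0.03 log units; within the scatter): methyl in place of hydrogen on a saturated chain carbon bound to two saturated chain carbons, which turns propoxy into isobutoxy, leaves compound 3 indistinguishable from compound 1. Going by these compounds alone, the earlier compounds offered no pair that differed in one place, so this is the only evidence that this branching of the chain produces no readable shift in this assay. Nothing measured here bears on why the number stays put. The compounds shown leave open whether a longer chain, or an amine or a carboxylic acid carried on the chain, would move the number beyond the scatter. They also do not show whether methyl at another carbon of the chain would behave the same way.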